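Replacing the carboxymethyl of compound 2 with hydroxy

The source may report more compounds than this note shows. Statements on the series, on what has been measured and on what is new or still open speak of the compounds shown alone.

Values in a functional assay on the whole organism for inhibition, with Rattus norvegicus as the target, read by paw edema, with stated times of 1 h and 3 h; a lower number here means that less compound is needed, a higher number that more compound is needed for the effect:
- compound 1 `C/C(=C\CC(=O)O)c1ccc(Cl)cc1`: 70 mg/kg
- compound 2 `C/C(=N\OCCCC(=O)O)c1ccc(Cl)cc1`: 58 mg/kg
- compound 3 `C/C(=N\OC(C)(C)C(=O)O)c1ccc(Cl)cc1`: 42 mg/kg

Compound 2 stands within the usual scatter of both compound 1 and compound 3, so these numbers give no ranking around it. The three compounds also differ in more than one place, and no clean single-change comparison exists among them.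

The next step leads to compound 4 `C/C(=N\OCCO)c1ccc(Cl)cc1`. Here hydroxy stands in place of carboxymethyl on a saturated chain carbon, two bonds along the chain from an oxygen (hydroxy in place of carboxymethyl on a saturated chain carbon, two bonds along the chain from an oxygen). Every measured compound carries a carboxylic acid, and compound 4 does not. Among the compounds with values here, the data therefore hold no direct precedent for this change, and the uncertainty is wide.

The starting point is compound 2 at 58 mg/kg, and the narrow spread of the measured values gives little reason to expect a large move. A small drift towards a higher number in this assay is expected, not clearly beyond the scatter. The expected step is a 1.4-fold higher number from compound 2 to compound 4 (0.14 log units; within the scatter). For compound 4 the estimated value is 80 mg/kg, with an expected range of 35 mg/kg to 190 mg/kg.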

Compound 4, dose for half-maximal effect: 29 mg/kg
The estimate for compound 4 lay 2.8-fold (0.44 log units) above the measured number; measured number below the stated range.
By their numbers in this assay, from the lowest: compounds 4, 3, 2 and 1 (each within the scatter of the next, the first and the last beyond it).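

In this assay the change from carboxymethyl to hydroxy on a saturated chain carbon, two bonds along the chain from an oxygen, gives a 2.0-fold lower number from compound 2 to compound 4 (0.30 log units; within the scatter) and so shows that the carboxylic acid carried by every earlier compound can leave this position without a step beyond the scatter. Within the data shown here, compound 4 is the first compound without that acid, and this single pair shows that a group of four heavy atoms can give way here to one of a single heavy atom with the read-out staying within the scatter. No measurement at hand accounts for this outcome, so it stands as an observation only.

As far as these compounds go, whether an amine, a methoxy or a primary amide at the same place would also stay within the scatter of compound 4 remains open. Also open, from the compounds shown here alone, is whether a longer chain ending in hydroxy reads the same way, and one pair fixes no rule for the series.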